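Methoxy for chloromethyl on the acyl chain of compound 1

The source may hold more compounds than are shown below. What is called first, only, known or untested is meant among the compounds shown, and "the series" means these compounds.

Measured compounds:
- compound 1, `COc1ccc(CN(C(=O)CCCl)c2cc(OC)c(OC)c(OC)c2)cc1O`: 150 nM
- compound 2, `COc1ccc(N(Cc2cc(OC)c(OC)c(OC)c2)C(=O)CCl)cc1O`: 22500 nM

In a functional assay on HCT-116 cells (Homo sapiens) for inhibition, read by MTT assay, with a stated time of 48 h (on this read-out higher numbers stand for weaker inhibition and lower numbers for stronger inhibition), compound 1 gives 150 nM, the lowest of the two numbers; compound 2 gives 22500 nM, a gap beyond the scatter. Compound 3, `COCC(=O)N(Cc1ccc(OC)c(O)c1)c1cc(OC)c(OC)c(OC)c1`, has not been measured. It differs from compound 1 by methoxy in place of chloromethyl on a saturated chain carbon bound to a carbonyl carbon. Going by the values given here, no measured pair isolates this change. Compound 3 is expected to lose some inhibition, with a step from a 3.3-fold higher number from compound 1 to compound 3 (0.52 log units; beyond the scatter), a modest shift in this assay. The estimate for compound 3 is 500 nM, within a range from 100 nM to 3000 nM.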

Compound 3, half-maximal inhibitory concentration: 230 nM
Compound 3: the middle estimate sits 2.2-fold (0.34 log units) above what was measured; measured number inside the range.
By their numbers in this assay, from the lowest: compounds 1 and 3 (each within the scatter of the next); then compound 2.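

In this assay, the swap of chloromethyl for methoxy on this saturated chain carbon bound to a carbonyl carbon gives a 1.5-fold higher number from compound 1 to compound 3 (0.19 log units; within the scatter). A number in this range therefore does not depend on the chlorine of compound 1, and this place accepts an oxygen-bearing chain in its stead. Nothing shown accounts for the two groups reading alike. Still open, as far as these compounds go, is whether an amine, a carboxylic acid or a longer chain at this place would also hold the number of compound 1.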